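Methyl for Methoxy in a Small Oxadiazole Series

A few compounds are considered here, and "the series" means these few. Any claim that something is new, unique, unknown or untested is made for them only; others in the source may bear on it.

Of the compounds shown here, three have been measured in a functional assay on MCF7 cells (Homo sapiens) for cytotoxicity, read by MTT assay, with a stated time of 48 h; on this read-out lower numbers stand for stronger inhibition and higher numbers for weaker inhibition. Compound 1 `COc1ccc(-c2nnc(COc3ccc(C#N)cc3OC)o2)cc1` gives 11100 nM in this assay. Compound 2 `COc1cc(C#N)ccc1OCc1nnc(-c2ccc(C)cc2)o1` gives 27100 nM in this assay. Compound 3 `COc1ccc(-c2nnc(COc3ccc(C#N)c(F)c3)o2)cc1` gives 42200 nM in this assay and stands with the highest number of the three, its gap to compound 2 within the scatter and its gap to compound 1 beyond it. The difference between the core of compound 1 and the core of compound 3 is not broken down here.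

Compound 1 and compound 2 differ in one place: methyl in place of methoxy on an aromatic carbon This change produced a 2.4-fold higher number from compound 1 to compound 2 (0.39 log units; beyond the scatter).

Compound 4 `Cc1ccc(-c2nnc(COc3ccc(C#N)c(F)c3)o2)cc1` has not yet been measured in this assay. It differs from compound 3 by the same change: methyl in place of methoxy on an aromatic carbon The surroundings of the place read the same word for word, so this is the same change, made on the core of compound 3.

Among the measured compounds shown here, with only one earlier example of this change, the expectation is a cautious one. The step expected in this assay is a 2.1-fold higher number from compound 3 to compound 4 (0.33 log units; beyond the scatter), which is meant to follow the earlier 2.4-fold higher number from compound 1 to compound 2 (0.39 log units; beyond the scatter). The number expected for compound 4 in this assay is 90000 nM, with a range from 40000 nM to 200000 nM. Compound 3 already gives 42200 nM, and the expectation for compound 4 is a higher number still.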

Compound 4, half-maximal inhibitory concentration: > 50000 nM
Compound 4: a limit, no number (the forecaster's own chance of this, stated with the estimate: 30%); the middle value lies beyond the limit too.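

In this assay compound 4 gives > 50000 nM, which is a limit of the assay and not a number. From the compounds shown here alone, the new step can therefore be read only as a floor, an at least 1.1-fold higher number from compound 3 to compound 4 (0.07 log units; that floor lies within the scatter), and it stands beside the earlier step as follows: the same change on two cores in this assay, a 2.4-fold higher number (0.39 log units; beyond the scatter) from compound 1 to compound 2 and an at least 1.1-fold higher number (0.07 log units; that floor lies within the scatter) from compound 3 to compound 4; the limit leaves it open whether they differ The result is compatible with methyl in place of methoxy carrying over to the core of compound 3, but it does not establish this, as the floor of the step does not clear the scatter and the true size of the step remains unknown.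

How far compound 4 lies past the limit stays open, and the series has little room at this end of the range: the limit of > 50000 nM in this assay, at which 1 of the 4 values shown sits. The compounds shown also leave open how the step would read with a chlorine, an ethyl group or an amine in place of methoxy, and whether any such change would carry from one core to the other.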